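A few compounds are considered here, and "the series" means these few. Any claim that something is new, unique, unknown or untested is made for them only; others in the source may bear on it.

Measured so far:
compound 1, `NS(=O)(=O)OC[C@@H]1C[C@@H](Nc2ncnc(N[C@H]3CCc4ccccc43)c2F)C[C@@H]1O` — 219 nM
compound 2, `NS(=O)(=O)OC[C@@H]1C[C@@H](n2nnc3c(NCc4ccccc4F)ncnc32)C[C@@H]1O` — 6.11 nM
compound 3, `NS(=O)(=O)OC[C@@H]1C[C@@H](n2nnc3c(NCc4cccs4)ncnc32)C[C@@H]1O` — 15.9 nM

In an assay on a protein complex for inhibition of NEDD8 activating enzyme (Homo sapiens), read by HTRF, with a stated time of 2 h, in the presence of a further agent that is not named here (on this read-out lower numbers stand for stronger inhibition and higher numbers for weaker inhibition), compound 2 gives the lowest of the three numbers; compound 3 is nearest, compound 1 furthest. Going by the values given here, the one single-point step in the set is a 2.6-fold higher number from compound 2 to compound 3 (0.42 log units; beyond the scatter). Compound 4, `NS(=O)(=O)OC[C@@H]1C[C@@H](n2nnc3c(NCCCc4ccccc4)ncnc32)C[C@@H]1O`, differs from compound 2 by phenethyl in place of 2-fluorophenyl on a saturated chain carbon bound to a nitrogen on an aromatic ring. Among the compounds with values here, only the step to compound 3 bears on this, and only loosely, since it also removes the 2-fluorophenyl; no measured pair changes the length of the chain between the amine nitrogen and the ring. A modest weakening is therefore expected, roughly a 2.9-fold higher number from compound 2 to compound 4 (0.47 log units; beyond the scatter). Compound 4 is estimated at 18 nM, within 5 nM to 70 nM.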

Compound 4, half-maximal inhibitory concentration: 149 nM
Beside the measured number, compound 4's estimate is 8.3-fold (0.92 log units) below it, and the stated range ends below it.
By their numbers in this assay, from the lowest: compound 2; then compound 3; then compounds 4 and 1 (each within the scatter of the next).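

The position on a saturated chain carbon bound to a nitrogen on an aromatic ring is far more sensitive than the thiophen-2-yl change suggested (a 2.6-fold higher number from compound 2 to compound 3 (0.42 log units; beyond the scatter)): 3-phenylpropyl in place of 2-fluorobenzyl gives a large loss (a 24-fold higher number from compound 2 to compound 4 (1.39 log units; beyond the scatter)). The same group also falls well short of the thiophen-2-yl compound (a 9.4-fold higher number from compound 3 to compound 4 (0.97 log units; beyond the scatter)). Nothing available explains this loss.

The fluorine and the chain length change together here, so their shares remain unresolved. A plain benzyl or a 2-phenylethyl group would help separate them.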